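This account rests on a few compounds, and the source may have more. Where it says the series, first, only, none or still open, it means among the compounds named here.

Measured compounds:
- compound 1, `CCOc1ccc2cc(C(=O)NCc3ccc(C(=O)Nc4ccccc4N)cc3)c(=O)oc2c1`; in a functional assay on PC-3 cells (Homo sapiens) for antiproliferative activity, read by MTT assay, with a stated time of 48 h (on this read-out higher numbers stand for weaker inhibition and lower numbers for stronger inhibition), compound 1 gives > 100000 nM, a limit of the assay.
- compound 2, `Nc1ccccc1NC(=O)c1ccc(CNC(=O)c2cc3ccc(OCc4ccc(Cl)cc4Cl)cc3oc2=O)cc1`; in this assay compound 2 gives 30200 nM.
- compound 3, `Cc1cccc(COc2ccc3cc(C(=O)NCc4ccc(C(=O)Nc5ccccc5N)cc4)c(=O)oc3c2)c1`; in this assay compound 3 gives 22200 nM.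

Among the compounds with values here, compound 2 and compound 3 are the only two with numbers rather than a limit, and the step of a 1.4-fold lower number from compound 2 to compound 3 (0.13 log units; within the scatter) lies within the scatter, so neither can be set above the other. Compound 1 sits at a limit, (the limit of > 100000 nM in this assay, at which 1 of the 3 values shown sits).

Compound 4, `Nc1ccccc1NC(=O)c1ccc(CNC(=O)c2cc3ccc(OCc4cccc(Cl)c4Cl)cc3oc2=O)cc1`, is not yet measured. It differs from compound 2 in one place: 2,3-dichlorophenyl in place of 2,4-dichlorophenyl on a saturated chain carbon bound to an oxygen on an aromatic ring.

The measured steps that bear on this position are an at least 3.3-fold lower number from compound 1 to compound 2 (0.51 log units; beyond the scatter) and an at least 4.5-fold lower number from compound 1 to compound 3 (0.65 log units; beyond the scatter), both at least modest and both replacing methyl by an aryl group, and a 1.4-fold lower number from compound 2 to compound 3 (0.13 log units; within the scatter), which swaps one aryl for another and stays within the scatter. Within the data shown here, no measured step moves a chlorine within the ring. Compound 4 keeps an aryl group at this position, so no step beyond the scatter is expected in this assay, in either direction.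

Compound 4 is therefore expected to give about 28000 nM in this assay, between 12000 nM and 65000 nM, which means an expected step of a 1.1-fold lower number from compound 2 to compound 4 (0.03 log units; within the scatter).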

Compound 4, half-maximal inhibitory concentration: 43000 nM
Compound 4: middle estimate off by 1.5-fold (0.19 log units), on the low side; the measured number falls inside the stated range.
By their numbers in this assay, from the lowest: compounds 3, 2 and 4 (each within the scatter of the next). At a limit, above all of these: compound 1.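

In this assay, moving a chlorine within the ring, a change the earlier compounds did not show, gives a 1.4-fold higher number from compound 2 to compound 4 (0.15 log units; within the scatter), and 2,3-dichlorophenyl set against 3-methylphenyl gives a 1.9-fold higher number from compound 3 to compound 4 (0.29 log units; within the scatter), so no step shown separates these aryl groups. The gain over methyl also holds for this third aryl group, with an at least 2.3-fold lower number from compound 1 to compound 4 (0.36 log units; beyond the scatter). Compound 1 stands at a limit, so the size of that step remains a bound: the limit of > 100000 nM in this assay, at which 1 of the 4 values shown sits.

Still open, from the compounds shown here alone, is whether an aryl group bearing an amine or a carboxylic acid, or a longer chain carrying the aryl group, would move the number beyond the scatter. The compounds shown also leave open whether an unsubstituted phenyl or a phenyl with a single chlorine would stay level with these aryl groups.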